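Pyrazole diesters bearing a coumarin: cytotoxicity on lung cells

The compounds below may be only part of what the source reports. "The series", "measured", "known", "first", "only" and "open" are said of these compounds alone.

Measured compounds:
Compound 1 `CCOC(=O)c1c(-c2cc3ccccc3oc2=O)nn(-c2cccc(F)c2)c1C(=O)OCC` gives 59000 nM in a functional assay on A549 cells (Homo sapiens) for cytotoxicity, read by MTT assay, with a stated time of 48 h; a higher number here means a weaker inhibitor, a lower number a stronger inhibitor.
Compound 2 `COC(=O)c1c(-c2cc3ccccc3oc2=O)nn(-c2cccc(F)c2)c1C(=O)OC` gives 50000 nM in this assay.
Compound 3 `CCOC(=O)c1c(-c2cc3ccccc3oc2=O)nn(-c2ccc(Br)cc2)c1C(=O)OCC` gives 100000 nM in this assay.

The three measured compounds share a core that carries a coumarin and two ester groups on a five-membered ring with two nitrogens, and an aryl group on one of those nitrogens. The numbers for compound 1, compound 2 and compound 3 all lie within the usual scatter of one another, so no ordering among them can be read from these data. The difference between the core of compound 1 and the core of compound 2 is not broken down here.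

One change is seen once among the measured compounds: 4-bromophenyl in place of 3-fluorophenyl on an aromatic nitrogen, which made the step of a 1.7-fold higher number from compound 1 to compound 3 (0.23 log units; within the scatter). Compound 4 `COC(=O)c1c(-c2cc3ccccc3oc2=O)nn(-c2ccc(Br)cc2)c1C(=O)OC` is not yet measured; it arises from compound 2 by 4-bromophenyl in place of 3-fluorophenyl on an aromatic nitrogen. This is the same kind of change as that from compound 1 to compound 3, though the place differs in that the ring atom next to it bears a methoxycarbonyl group in compound 2 and compound 4, whereas it bears an ethoxycarbonyl group in compound 1 and compound 3.

Resting on compound 2 at 50000 nM and on the earlier step of a 1.7-fold higher number from compound 1 to compound 3 (0.23 log units; within the scatter), the expected step for compound 4 is a 1.7-fold higher number from compound 2 to compound 4 (0.23 log units; within the scatter) in this assay. Compound 4 is therefore estimated at 85000 nM in this assay, with an expected range from 40000 nM to 180000 nM.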

Compound 4, half-maximal inhibitory concentration: 165000 nM
Compound 4: middle estimate off by 1.9-fold (0.29 log units), on the low side, and the stated range covers the measured number.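

In this assay, putting 4-bromophenyl in place of 3-fluorophenyl on the core with two methoxycarbonyl groups gave a 3.3-fold higher number from compound 2 to compound 4 (0.52 log units; beyond the scatter). Set beside the same change on the core with two ethoxycarbonyl groups, the new step does not differ from the earlier one by more than the scatter of two such steps allows: the same change on two cores in this assay, a 1.7-fold higher number (0.23 log units; within the scatter) from compound 1 to compound 3 and a 3.3-fold higher number (0.52 log units; beyond the scatter) from compound 2 to compound 4, 1.9-fold (0.29 log units) apart, within the scatter of two such steps. Among the compounds shown here, this shows that, for this one pair of cores, a single expected step fits both cases and nothing marks the ester group as altering the effect of the change, but it rests on only two steps, one within the scatter and one beyond it, so it does not show that the change would carry to other cores, and it cannot separate the swap of fluorine for bromine from the shift in where the halogen sits on the phenyl ring.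

The compounds shown leave open how 3-bromophenyl, 4-fluorophenyl or an unsubstituted phenyl group on the aromatic nitrogen would compare, which would pull those two parts of the change apart. They also leave open what a carboxylic acid or an amide in place of the esters would do in this assay.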